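Difluorophenyl Ether Swap Tested on a Chlorophenyl Thiazole

The compounds below may be only part of what the source reports. "The series", "measured", "known", "first", "only" and "open" are said of these compounds alone.

Compound 1 `Cc1ccc(-c2csc(NC(=O)COc3ccccc3C)n2)cc1` and compound 2 `Cc1ccc(-c2csc(NC(=O)COc3ccc(F)cc3F)n2)cc1` share a core and differ only at the ether: 2,4-difluorophenyl in place of 2-methylphenyl on an oxygen on a saturated carbon. In a functional assay on A549 cells (Homo sapiens) for cytotoxicity, read by MTT assay, with a stated time of 48 h (on this read-out higher numbers stand for weaker inhibition and lower numbers for stronger inhibition), compound 1 gives 50900 nM, and compound 2 gives 13900 nM, so that the step is a 3.7-fold lower number from compound 1 to compound 2 (0.56 log units; beyond the scatter). Compound 3 `Cc1ccccc1OCC(=O)Nc1nc(-c2ccc(Cl)cc2)cs1` differs from compound 1 by chloro in place of methyl on an aromatic carbon, and in this assay compound 3 gives 64900 nM, with the step being a 1.3-fold higher number from compound 1 to compound 3 (0.11 log units; within the scatter). Compound 4 `O=C(COc1ccc(F)cc1F)Nc1nc(-c2ccc(Cl)cc2)cs1` has not yet been measured; it differs from compound 3 by 2,4-difluorophenyl in place of 2-methylphenyl on an oxygen on a saturated carbon, the same change as that from compound 1 to compound 2, made at the same place. Within the data shown here, for compound 4 the expected step is a 3.7-fold lower number from compound 3 to compound 4 (0.57 log units; beyond the scatter), which rests on the single earlier instance, a 3.7-fold lower number from compound 1 to compound 2 (0.56 log units; beyond the scatter). In this assay compound 4 is estimated at 17500 nM, expected to lie between 7000 nM and 45000 nM.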

Compound 4, half-maximal inhibitory concentration: 26500 nM
Compound 4: the middle estimate sits 1.5-fold (0.18 log units) below what was measured, within the range that was stated.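

On the core of compound 3 the ether change again gives a lower number in this assay, with a 2.4-fold lower number from compound 3 to compound 4 (0.39 log units; beyond the scatter), and its size agrees with the earlier instance: the same change on two cores in this assay, a 3.7-fold lower number (0.56 log units; beyond the scatter) from compound 1 to compound 2 and a 2.4-fold lower number (0.39 log units; beyond the scatter) from compound 3 to compound 4, 1.5-fold (0.17 log units) apart, within the scatter of two such steps. The other change, chloro in place of methyl on an aromatic carbon, stays within the scatter with 2,4-difluorophenyl on the oxygen, with a 1.9-fold higher number from compound 2 to compound 4 (0.28 log units; within the scatter), as it did with 2-methylphenyl: the same change on two cores in this assay, a 1.3-fold higher number (0.11 log units; within the scatter) from compound 1 to compound 3 and a 1.9-fold higher number (0.28 log units; within the scatter) from compound 2 to compound 4, 1.5-fold (0.17 log units) apart, within the scatter of two such steps. This shows that the ether change carried over between these two cores, but it does not show that it would hold on any other core or in any other cell line.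

The compounds shown leave open whether an unsubstituted phenyl or a pyridine ring on the oxygen would give a similar step. They also leave open how a methoxy group or a nitrile in place of the chloro would behave.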